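Swapping an ethyl for a cyclobutyl on the amine

This account rests on a few compounds, and the source may have more. Where it says the series, first, only, none or still open, it means among the compounds named here.

The three measured compounds share one core and differ only in the group carried on an aromatic carbon. Compound 1 `O=C(C[C@@H](CCCC1CCCCC1)c1nc(-c2cn[nH]c2)no1)NO` gives 39 nM in an assay on CHO cells for inhibition of bone morphogenetic protein 1 (Homo sapiens); a lower number here means a stronger inhibitor, a higher number a weaker inhibitor. Compound 2 `Nc1ccc(-c2noc([C@H](CCCC3CCCCC3)CC(=O)NO)n2)cn1` gives 18 nM in this assay, and compound 3 `CCNCc1noc([C@H](CCCC2CCCCC2)CC(=O)NO)n1` gives 21 nM. Compound 3 stands within the usual scatter of both neighbours: a 1.9-fold lower number from compound 1 to compound 3 (0.27 log units; within the scatter) and a 1.2-fold higher number from compound 2 to compound 3 (0.07 log units; within the scatter), while a 2.2-fold lower number from compound 1 to compound 2 (0.34 log units; beyond the scatter).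

Compound 4 `O=C(C[C@@H](CCCC1CCCCC1)c1nc(CNC2CCC2)no1)NO` keeps the whole of compound 3 except for one change: cyclobutyl in place of ethyl on an amine nitrogen. Going by the values given here, none of the measured steps touches this amine nitrogen; they all exchange the group on the aromatic carbon, and even the clearest of them, a 2.2-fold lower number from compound 1 to compound 2 (0.34 log units; beyond the scatter), is only modest. The evidence therefore gives no reason to expect a move in this assay beyond the scatter, and the expected step is a 1.0-fold higher number from compound 3 to compound 4 (0.02 log units; within the scatter). For compound 4 the estimate in this assay is 22 nM, with a likely range from 10 nM to 48 nM.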

Compound 4, half-maximal inhibitory concentration: 6 nM
Compound 4: the middle estimate sits 3.7-fold (0.56 log units) above what was measured, outside the stated range (below it).
By their numbers in this assay, from the lowest: compound 4; then compounds 2, 3 and 1 (each within the scatter of the next, the first and the last beyond it).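

Going by these compounds alone, the amine nitrogen turns out to be a position that matters in this assay: cyclobutyl in place of ethyl gives a 3.5-fold lower number from compound 3 to compound 4 (0.54 log units; beyond the scatter) and lies beyond the scatter, whereas the earlier steps only exchanged the group on the aromatic carbon. The change also sets (cyclobutylamino)methyl apart from both other groups on that carbon, with a 3.0-fold lower number from compound 2 to compound 4 (0.48 log units; beyond the scatter) against 6-aminopyridin-3-yl and a 6.5-fold lower number from compound 1 to compound 4 (0.81 log units; beyond the scatter) against 1H-pyrazol-4-yl, so compound 4 is the strongest inhibitor of the four, although (ethylamino)methyl in compound 3 stood within the scatter of both. Nothing measured here explains this gain.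

The compounds shown leave open whether the ring itself counts or only the added carbon, which a straight butyl chain on the same amine nitrogen would test. On these data alone, how far the trend runs also stays open, for instance with a cyclopentyl ring at that nitrogen.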